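Furan Isomer Swap on a Nucleoside Scaffold With Limits Only

The source may hold more compounds than are shown below. What is called first, only, known or untested is meant among the compounds shown, and "the series" means these compounds.

Compound 1 `Cc1nc(N)c2c(-c3ccco3)cn([C@@H]3O[C@H](CO)[C@@H](O)[C@H]3O)c2n1`: this assay, > 20000 nM (a limit of the assay).
Compound 2 `Nc1nc(N)c2c(-c3ccccc3)cn([C@@H]3O[C@H](CO)[C@@H](O)[C@H]3O)c2n1`: this assay, > 20000 nM (a limit of the assay).
Compound 3 `Nc1nc(N)c2c(-c3ccoc3)cn([C@@H]3O[C@H](CO)[C@@H](O)[C@H]3O)c2n1`: this assay, > 20000 nM (a limit of the assay).

In a functional assay on CEM-DNR-bulk cells (Homo sapiens), read by MTT assay, with a stated time of 72 h (on this read-out lower numbers stand for stronger inhibition and higher numbers for weaker inhibition), compound 3 gives only a limit, > 20000 nM, and not a number. The two other measured compounds likewise give only limits, so compound 3 cannot be placed above or below either of them. The step that the two limits leave unreadable from compound 2 to compound 3 is therefore unreadable in size and direction. The account now turns to compound 4 `Nc1nc(N)c2c(-c3ccco3)cn([C@@H]3O[C@H](CO)[C@@H](O)[C@H]3O)c2n1`, which is not yet measured. It differs from compound 3 as furan-2-yl in place of furan-3-yl on an aromatic carbon. No measured step separates a furan-2-yl from a furan-3-yl at this position, so nothing shown bears directly on the size of this step. What is shown is the limit of > 20000 nM in this assay, at which 3 of the 3 values shown sit, and compound 1 carries the same furan-2-yl group. Compound 4 is thus expected to give 30000 nM in this assay, with a range from 12000 nM to 100000 nM. The expected step that the limit leaves unreadable from compound 3 to compound 4 is no larger than the scatter, and a limit rather than a number is expected as the most likely outcome.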

Compound 4, half-maximal inhibitory concentration: > 20000 nM
Compound 4 was reported as a limit; the forecaster's own chance of this, stated with the estimate: 85%; the middle value does not contradict the limit.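

In this assay compound 4 gives > 20000 nM, a limit of the assay, so its steps from compound 1, compound 2 and compound 3 cannot be read. The compounds shown leave open whether furan-2-yl, furan-3-yl and phenyl differ at all in this assay.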